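The compounds below may be only part of what the source reports. "The series", "measured", "known", "first", "only" and "open" are said of these compounds alone.

Measured so far:
Compound 1 `Cc1ccc(-c2cs/c(=N/NC(=O)CSc3nnnn3-c3ccccc3)n2-c2ccccc2)cc1` — in an ADME assay on NIH3T3 cells (Mus musculus) for cytotoxicity, read by MTT assay, with a stated time of 24 h (a higher number here means a weaker inhibitor, a lower number a stronger inhibitor), compound 1 reaches only the assay limit, > 500 ug/mL.
Compound 2 `O=C(CSc1nnnn1-c1ccccc1)N/N=c1/scc(-c2ccccc2)n1-c1ccccc1` — in this assay compound 2 gives 417 ug/mL.
Compound 3 `Cn1nnnc1SCC(=O)N/N=c1/scc(-c2ccc([N+](=O)[O-])cc2)n1-c1ccccc1` — in this assay compound 3 gives 167 ug/mL.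

Compound 3 holds the lowest of the two numbers; compound 2 stands a step beyond the scatter higher. Compound 1 sits at the limit (the limit of > 500 ug/mL in this assay, at which 1 of the 3 values shown sits), which is a limit and not a number. Compound 4 `O=C(CSc1nnnn1-c1ccccc1)N/N=c1/scc(-c2ccc([N+](=O)[O-])cc2)n1-c1ccccc1` differs from compound 3 by phenyl in place of methyl on an aromatic nitrogen. Among the measured compounds shown here, the one measured step, an at least 1.1-fold lower number from compound 1 to compound 2 (0.07 log units; that floor lies within the scatter), concerns a different position and lies within the scatter, so it does not bear on this change; no measured pair separates a methyl from a phenyl on the aromatic nitrogen. For compound 4 a step of about a 1.5-fold higher number from compound 3 to compound 4 (0.18 log units; within the scatter) is expected, that is, nothing clearly beyond the scatter. Compound 4 is therefore estimated at 250 ug/mL, in a range from 120 ug/mL to 520 ug/mL.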

Compound 4, half-maximal inhibitory concentration: 14.3 ug/mL
Compound 4: middle estimate off by 17-fold (1.24 log units), on the high side; the measured number lies below the stated range.
By their numbers in this assay, from the lowest: compound 4; then compound 3; then compound 2. At a limit, above all of these: compound 1.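

Replacing 1-methyl-1H-tetrazol-5-yl with 1-phenyl-1H-tetrazol-5-yl gives a 12-fold lower number from compound 3 to compound 4 (1.07 log units; beyond the scatter) in this assay, so the group on this aromatic nitrogen can shift the number well beyond the scatter. With phenyl held in place, nitro in place of hydrogen on an aromatic carbon gives a 29-fold lower number from compound 2 to compound 4 (1.46 log units; beyond the scatter), and nitro in place of methyl there gives an at least 34-fold lower number from compound 1 to compound 4 (1.54 log units; beyond the scatter), so that carbon position matters too. Compound 1 stands at a limit, not a number: the limit of > 500 ug/mL in this assay, at which 1 of the 4 values shown sits.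

Still open, from the compounds shown here alone, is how an ethyl or benzyl group on the aromatic nitrogen, or an amine in place of nitro on the aromatic carbon, would read.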